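Changing the Amide Aryl Group: Expected Cytotoxicity of Compound 4

The source may hold more compounds than are shown below. What is called first, only, known or untested is meant among the compounds shown, and "the series" means these compounds.

Of the compounds shown here, three sharing one core have been tested in an ADME assay on HEp-2 cells (Homo sapiens) for cytotoxicity; on this read-out lower numbers stand for higher toxicity in this test and higher numbers for lower toxicity in this test. Compound 1 `Cc1ccc(NC(=O)CNS(=O)(=O)c2cccc3cccnc23)c(C)c1` gives only a limit in this assay, > 50000 nM. Compound 2 `Cc1ccc(NC(=O)[C@@H]2CCCN2S(=O)(=O)c2cccc3cccnc23)cc1` gives 31700 nM in this assay, and compound 3 `O=C(Nc1ccccc1)[C@@H]1CCCN1S(=O)(=O)c1cccc2cccnc12` gives 35600 nM. Going by the values given here, compound 2 and compound 3 thus sit together, the single measured step, a 1.1-fold higher number from compound 2 to compound 3 (0.05 log units; within the scatter), staying within the scatter. The remaining value, that of compound 1, is a limit (the limit of > 50000 nM in this assay, at which 1 of the 3 values shown sits). Compound 4 `CC(C)c1ccccc1NC(=O)[C@@H]1CCCN1S(=O)(=O)c1cccc2cccnc12` differs from compound 2 by 2-isopropylphenyl in place of 4-methylphenyl on an amide-type nitrogen. Among the compounds with values here, no measured step covers this exact change, and the one step known shows that a small alteration of the aryl group left the number in place. A step no larger than the scatter is therefore expected, a 1.3-fold lower number from compound 2 to compound 4 (0.10 log units; within the scatter). Compound 4 is estimated at 25000 nM, between 10000 nM and 60000 nM.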

Compound 4, half-maximal cytotoxic concentration: 29900 nM
Compound 4: middle estimate off by 1.2-fold (0.08 log units), on the low side, and the stated range covers the measured number.
By their numbers in this assay, from the lowest: compounds 4, 2 and 3 (each within the scatter of the next). At a limit, above all of these: compound 1.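

Going by these compounds alone, until now, the only change seen on this aryl group was hydrogen in place of methyl. In this assay the change to 2-isopropylphenyl on the amide-type nitrogen gives a 1.1-fold lower number from compound 2 to compound 4 (0.03 log units; within the scatter) and isopropyl in place of hydrogen on an aromatic carbon gives a 1.2-fold lower number from compound 3 to compound 4 (0.08 log units; within the scatter) on the same aryl group, so a larger alkyl-bearing aryl group also leaves the number within the scatter. Nothing measured here offers a reason for this. The compounds shown leave open whether an amine or a carboxylic acid on this aryl group, in place of the alkyl groups seen so far, would move the number beyond the scatter.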